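Chlorine for Fluorine on the Benzyl Ring of Compound 3

The source may hold more compounds than are shown below. What is called first, only, known or untested is meant among the compounds shown, and "the series" means these compounds.

Measured compounds:
compound 1, `Cc1cc(-c2sc(Cc3cccc(C(F)(F)F)c3)nc2C)ccc1C(N)=O`, 86%
compound 2, `COc1cccc(Cc2nc(C)c(-c3ccc(C(N)=O)c(C)c3)s2)c1`, 85%
compound 3, `Cc1cc(-c2sc(Cc3cccc(F)c3)nc2C)ccc1C(N)=O`, 75%

The three compounds share one core and differ only in the group on the benzyl ring. In a functional assay on cells for agonist activity at G-protein coupled receptor 52 (Homo sapiens), read by AlphaScreen and cAMP accumulation, with a stated time of 30 min (on this read-out higher numbers stand for larger maximal responses and lower numbers for smaller maximal responses), compound 3 has the lowest of the three numbers, although its step from compound 2 lies within the scatter: a number 10 percentage points lower from compound 2 to compound 3 (within the scatter). Its step from compound 1 is somewhat larger: a number 11 percentage points lower from compound 1 to compound 3 (beyond the scatter). The two larger groups sit close together: a number 1 percentage points lower from compound 1 to compound 2 (within the scatter).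

Compound 4, `Cc1cc(-c2sc(Cc3cccc(Cl)c3)nc2C)ccc1C(N)=O`, is not yet measured. Its change from compound 3 is chloro in place of fluoro on an aromatic carbon. All three measured steps bear on it, as each swaps the group at this same place, and none moved the maximal response by much: only the swap from trifluoromethyl to fluoro reached beyond the scatter, and only just. A halogen for a halogen at the same place is therefore expected to give a step that is small and, if anything, upward: a number 6 percentage points higher from compound 3 to compound 4 (within the scatter). Compound 4 is expected to reach about 81% in this assay, within a range from 70% to 92%.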

Compound 4, largest response reached (Emax), in percent of the reference or control that the assay uses: 75%
For compound 4 the middle estimate is 6 percentage points above the measured one; measured number inside the range.
By their numbers in this assay, from the lowest: compounds 3, 4, 2 and 1 (each within the scatter of the next, the first and the last beyond it).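

In this assay, among these compounds, chloro in place of fluoro on this benzyl ring gives no change at the digits printed from compound 3 to compound 4 (within the scatter) and so adds something the earlier compounds could not show, since they held only one halogen: at this place, the two halogens give the same maximal response at the digits printed. Compound 4 also stands where compound 3 stood against the other two groups, with a number 10 percentage points lower from compound 2 to compound 4 (within the scatter) on the methoxy side and a number 11 percentage points lower from compound 1 to compound 4 (beyond the scatter) on the trifluoromethyl side, so compound 1 is the only one of the four set apart from both halogen compounds, and only modestly. Nothing available explains why the chloro and fluoro compounds match.

Open, going by these compounds, is whether this flat picture would hold for other kinds of group at this place, such as a bromo, a hydroxyl, an amine or a carboxylic acid, or a longer chain such as ethoxy. Also open, on these data alone, is whether chloro and fluoro would still match elsewhere on this ring, or on a different core.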